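Swapping cyclohexyl for methyl on the shared core

The source may report more compounds than this note shows. Statements on the series, on what has been measured and on what is new or still open speak of the compounds shown alone.

Compound 1 `c1cc(C2CCCCC2)ccc1NC1=NCCO1` gives 17800 nM
Compound 2 `c1ccc(Oc2ccc(NC3=NCCO3)cc2)cc1` gives 3100 nM

In a functional assay on M21 cells (Homo sapiens) for inhibition, read by sulforhodamine B assay, with a stated time of 48 h (a lower number here means a stronger inhibitor of growth, a higher number a weaker inhibitor of growth), compound 1 stands highest of the two at 17800 nM and is the weaker inhibitor of growth. Compound 2 gives 3100 nM and is the stronger inhibitor of growth. The gap between the two compounds lies beyond the usual scatter. Compound 3 `Cc1ccc(NC2=NCCO2)cc1` has methyl in place of cyclohexyl on an aromatic carbon. Among the compounds with values here, no measured pair shows this change alone, so the size of the step is uncertain. A modest rise in the number is expected, pointing to weaker inhibition of growth (a 2.0-fold higher number from compound 1 to compound 3 (0.29 log units; within the scatter) is the estimated step). In this assay the estimate for compound 3 is 35000 nM (expected range 12000 nM to 100000 nM).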

Compound 3, concentration for 50% growth inhibition: 22000 nM
The estimate for compound 3 lay 1.6-fold (0.20 log units) above the measured number, and the stated range covers the measured number.
By their numbers in this assay, from the lowest: compound 2; then compounds 1 and 3 (each within the scatter of the next).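

Replacing cyclohexyl with methyl on this aromatic carbon gives a 1.2-fold higher number from compound 1 to compound 3 (0.09 log units; within the scatter) in this assay, so this change makes no clear difference to growth inhibition. Going from 6 heavy atoms and a ring to a single carbon with no ring therefore does not separate these two compounds. No measurement offers an explanation for this result. Still open, as far as these compounds go, is how an amine, a carboxylic acid or a longer alkyl chain at this position would read in this assay, and whether any of them would shift the number beyond the scatter.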